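The source may report more compounds than this note shows. Statements on the series, on what has been measured and on what is new or still open speak of the compounds shown alone.

Compound 1 `CCCCOc1ccc(NS(=O)(=O)c2ccc(N3CCNC3=O)cc2)cc1` — 580 nM
Compound 2 `O=C1NCCN1c1ccc(S(=O)(=O)Nc2ccc(F)c(F)c2)cc1` — 220 nM
Compound 3 `CCCCCCOc1ccc(NS(=O)(=O)c2ccc(N3CCNC3=O)cc2)cc1` — > 1000 nM

In a functional assay on M21 cells (Homo sapiens) for antiproliferative activity, read by sulforhodamine B assay, with a stated time of 48 h (a lower number here means a stronger inhibitor, a higher number a weaker inhibitor), compound 2 gives 220 nM, the lower of the two numbers given, and the gap to compound 1 is beyond the scatter. Compound 3 reaches only a limit of the assay, (the limit of > 1000 nM in this assay, at which 1 of the 3 values shown sits), so its value is not a number. Going by the values given here, the one step told between measured compounds is an at least 1.7-fold higher number from compound 1 to compound 3 (0.23 log units; that floor lies within the scatter), a lengthening of a chain that goes no further than the floor set by that limit.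

Compound 4 `Cc1cccc(NS(=O)(=O)c2ccc(N3CCNC3=O)cc2)c1` differs from compound 2 in one place: 3-methylphenyl in place of 3,4-difluorophenyl on a sulfonamide nitrogen. Among the compounds with values here, no measured step touches this part of the molecule, so the only guide is that compound 2 sits at the better end of what has been measured and that any move away from it so far gave a higher number. The expected step is a 2.3-fold higher number from compound 2 to compound 4 (0.36 log units; beyond the scatter), a modest weakening. Compound 4 is therefore estimated at 500 nM, within 150 nM to 1500 nM.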

Compound 4, half-maximal inhibitory concentration: 69 nM
Compound 4: the middle estimate sits 7.2-fold (0.86 log units) above what was measured, and the stated range ends above it.
By their numbers in this assay, from the lowest: compound 4; then compound 2; then compound 1. At a limit, above all of these: compound 3.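

In this assay putting 3-methylphenyl in place of 3,4-difluorophenyl on a sulfonamide nitrogen gives a 3.2-fold lower number from compound 2 to compound 4 (0.50 log units; beyond the scatter) and so shows that the group at this place can move the number down by more than the usual scatter. The fluorine atoms of compound 2 are therefore not needed for a low number in this pair, and the methyl group of compound 4 does better than both of them together. Nothing measured here explains this gain.

As far as these compounds go, the swap removes the fluorine atoms and adds the methyl group in one change, so the share of each in the step stays unknown. From the compounds shown here alone, it also remains open whether a methoxy group, an amine or a carboxylic acid on that aromatic ring would give a lower number or a higher one.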